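This account rests on a few compounds, and the source may have more. Where it says the series, first, only, none or still open, it means among the compounds named here.

Compound 1 `CCC1=C(O)c2c(oc(-c3ccc(C)cc3)cc2=O)C(CC)(CC)C1=O` gives the lowest of the two numbers in a functional assay on KBVIN cells (Homo sapiens) for antiproliferative activity, read by sulforhodamine B assay, with a stated time of 3 days (on this read-out higher numbers stand for an effect only at larger amounts of compound and lower numbers for an effect already at smaller amounts), with compound 1 at 0.08 uM; compound 2 `CCC1=C(O)c2c(oc(-c3ccc(C)c(C)c3)cc2=O)C(CC)(CC)C1=O` gives 0.71 uM. Compound 3 `CCC1=C(O)c2c(oc(-c3ccc(OC)c(C)c3)cc2=O)C(CC)(CC)C1=O` differs from compound 1 by 4-methoxy-3-methylphenyl in place of 4-methylphenyl on an aromatic carbon. Among the measured compounds shown here, the one step that bears on this change is an 8.9-fold higher number from compound 1 to compound 2 (0.95 log units; beyond the scatter), since compound 3 also carries that methyl; no step shows what the methoxy group does. A higher number is therefore expected, with compound 3 estimated at 0.5 uM, between 0.12 uM and 2.5 uM, meaning an expected 6.3-fold higher number from compound 1 to compound 3 (0.80 log units; beyond the scatter).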

Compound 3, concentration for half-maximal effect: 0.1 uM
Beside the measured number, compound 3's estimate is 5.0-fold (0.70 log units) above it, and the stated range ends above it.
By their numbers in this assay, from the lowest: compounds 1 and 3 (each within the scatter of the next); then compound 2.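

The ring's methyl does not decide the outcome alone: with that methyl kept, methoxy in place of the other methyl gives (a 7.1-fold lower number from compound 2 to compound 3 (0.85 log units; beyond the scatter)). Against the 4-methylphenyl group, the 4-methoxy-3-methylphenyl group gives (a 1.3-fold higher number from compound 1 to compound 3 (0.10 log units; within the scatter)), so the rise seen for compound 2 does not carry over to every ring bearing that methyl. Nothing measured here explains this difference. Still open, going by these compounds, is what methoxy does without the added methyl, as in a 4-methoxyphenyl group, and whether a longer chain such as ethoxy, or an amine, is accepted at this place.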